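The compounds below may be only part of what the source reports. "The series", "measured", "known", "first", "only" and "open" are said of these compounds alone.

Going by the values given here, compound 2 `CC(=O)O[C@H]1C[C@@H](C)C=C2C=C[C@H](C)[C@H](CC[C@@H]3C[C@@H](O)CC(=O)O3)C21` gives 269 nM in an assay for inhibition of 3-hydroxy-3-methylglutaryl-coenzyme A reductase (Rattus norvegicus) (a lower number here means a stronger inhibitor, a higher number a weaker inhibitor), the higher of the two numbers known so far. Compound 1 `CC(C)C(=O)O[C@H]1C[C@@H](C)C=C2C=C[C@H](C)[C@H](CC[C@@H]3C[C@@H](O)CC(=O)O3)C21` gives 7.7 nM in this assay, and the step of a 35-fold higher number from compound 1 to compound 2 (1.54 log units; beyond the scatter) is large and beyond the scatter. Compound 3 `C[C@H]1C=C2C=C[C@H](C)[C@H](CC[C@@H]3C[C@@H](O)CC(=O)O3)C2[C@@H](OC(=O)C2CC2)C1` differs from compound 2 by cyclopropyl in place of methyl on a carbonyl carbon. Among the compounds with values here, only that one step bears on this change, and it shows that the isopropyl of compound 1 went with a far lower number than the methyl of compound 2. A step of the same direction, somewhat smaller, is therefore expected: a 13-fold lower number from compound 2 to compound 3 (1.13 log units; beyond the scatter). Compound 3 is expected to give 20 nM, within 6 nM to 70 nM.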

Compound 3, half-maximal inhibitory concentration: 38.6 nM
Compound 3: middle estimate off by 1.9-fold (0.29 log units), on the low side; measured number inside the range.
By their numbers in this assay, from the lowest: compound 1; then compound 3; then compound 2.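

With cyclopropyl on this carbonyl carbon, the step of a 7.0-fold lower number from compound 2 to compound 3 (0.84 log units; beyond the scatter) in this assay shows that a second group besides isopropyl goes with a lower number than methyl, while the step of a 5.0-fold higher number from compound 1 to compound 3 (0.70 log units; beyond the scatter) leaves cyclopropyl short of isopropyl. The two groups are therefore not interchangeable here, and the order at this position runs isopropyl, cyclopropyl, methyl. Nothing at hand explains that order. The compounds shown leave open how a longer chain, a tert-butyl group or an amine on this carbonyl carbon would compare with isopropyl.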